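Phenyl for Vinyl: Expected Growth Inhibition of Compound 3

The source may report more compounds than this note shows. Statements on the series, on what has been measured and on what is new or still open speak of the compounds shown alone.

Measured compounds:
Compound 1 `CC(C)COC(=O)Nc1ccc([Se][Se]c2ccc(NC(=O)OCC(C)C)cc2)cc1` gives 19900 nM in a functional assay on HT-29 cells (Homo sapiens) for cytotoxicity, read by MTT assay, with a stated time of 72 h; on this read-out lower numbers stand for stronger inhibition of growth and higher numbers for weaker inhibition of growth.
Compound 2 `C=CCOC(=O)Nc1ccc([Se]C#N)cc1` gives 24500 nM in this assay.

Compound 2 holds the higher of the two numbers in this assay; its nearest neighbour is compound 1, whose number is lower by an amount within the scatter, so the two cannot be told apart. Compound 3 `N#C[Se]c1ccc(NC(=O)OCc2ccccc2)cc1` differs from compound 2 by one change: phenyl in place of vinyl on a saturated chain carbon bound to an oxygen next to a carbonyl group. Going by the values given here, no measured pair shows this change, so its effect is unknown. Because compound 1 gives 19900 nM and compound 2 gives 24500 nM although they differ in several places, a single change of this kind is expected to move the number in this assay little, in no clear direction and not beyond the scatter. Compound 3 is therefore estimated at 22000 nM, with a range from 8000 nM to 60000 nM. The expected step of a 1.1-fold lower number from compound 2 to compound 3 (0.05 log units; within the scatter) is thus small.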

Compound 3, concentration for 50% growth inhibition: 13300 nM
Estimate against measurement, compound 3: 1.7-fold (0.22 log units) above; low and high end bracket the measured number.
By their numbers in this assay, from the lowest: compounds 3, 1 and 2 (each within the scatter of the next).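

Going by these compounds alone, the first pair to show this change gives a 1.8-fold lower number from compound 2 to compound 3 (0.27 log units; within the scatter) in this assay for phenyl in place of vinyl on a saturated chain carbon bound to an oxygen next to a carbonyl group. The numbers of the two compounds therefore cannot be told apart, and this place takes a six-membered aromatic ring of carbon only without a step beyond the scatter. This single pair does not give the direction of any effect, and no measurement shown explains the result.

The compounds shown leave open whether an amine, a carboxylic acid or a longer chain in place of phenyl at this place would give a step beyond the scatter. They also leave open whether phenyl in place of the chain of compound 1 would give a similar result on the core of that compound.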